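Fluorine on the Benzyl Ring of Compound 2

A few compounds are considered here, and "the series" means these few. Any claim that something is new, unique, unknown or untested is made for them only; others in the source may bear on it.

Compound 1, `C1CCC(CN[C@H]2C3C4CC5C6C4CC3C6C52)CC1`: 4 nM
Compound 2, `CN(Cc1ccccc1)[C@H]1C2C3CC4C2C(=O)C2C4C3C21`: 568 nM

Of the compounds shown here, two have been measured in an assay on brain for displacement of a labelled ligand from Sigma non-opioid intracellular receptor 1 (Rattus norvegicus); on this read-out lower numbers stand for stronger inhibition and higher numbers for weaker inhibition. Compound 1 gives 4 nM, while compound 2 gives 568 nM. Of the two numbers, that of compound 2 is the higher, and the gap between compound 2 and compound 1 lies beyond the scatter. Compound 3 `CN(Cc1cccc(F)c1)[C@H]1C2C3CC4C2C(=O)C2C4C3C21` differs from compound 2 in one place: fluoro in place of hydrogen on an aromatic carbon. Within the data shown here, no step between measured compounds covers this change, so the expectation rests on compound 2 alone. The step from compound 2 to compound 3 is expected to be small, a 1.1-fold lower number from compound 2 to compound 3 (0.06 log units; within the scatter), within the scatter. Compound 3 is therefore estimated at 500 nM in this assay, with a range from 200 nM to 1400 nM.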

Compound 3, inhibition constant: 303 nM
Estimate against measurement, compound 3: 1.7-fold (0.22 log units) above, and the stated range covers the measured number.
By their numbers in this assay, from the lowest: compound 1; then compounds 3 and 2 (each within the scatter of the next).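

The change from phenyl to 3-fluorophenyl gives a 1.9-fold lower number from compound 2 to compound 3 (0.27 log units; within the scatter) in this assay, so compound 2 and compound 3 cannot be told apart on this read-out. Among these compounds, this is the first view of the aromatic ring, and it shows that fluoro can sit on this carbon without a measurable difference in binding. Nothing on hand bears on the reason for this result.

On these data alone, whether chlorine or a methoxy group on the same carbon would give a step beyond the scatter stays open. So does the outcome of fluoro on the other carbons of the ring.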